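Aryl Amide Swap: Fluorophenyl to Trifluoromethylphenyl

A few compounds are considered here, and "the series" means these few. Any claim that something is new, unique, unknown or untested is made for them only; others in the source may bear on it.

Compound 2 `COc1ccc(-n2nc(C(=O)Nc3cccc(F)c3)nc2-c2cc(OC)c(OC)c(OC)c2)cc1` stands highest of the two numbers measured in a functional assay on the whole organism for inhibition, with Rattus norvegicus as the target, read by paw edema, with stated times of 30 min and 4 h, at a dose of 0.28 mmol/kg by the oral route; on this read-out higher numbers stand for more inhibition at the one dose given (going by the name of the read-out) and lower numbers for less inhibition: compound 2 gives 70%, while compound 1 `CCNC(=O)c1nc(-c2cc(OC)c(OC)c(OC)c2)n(-c2ccc(OC)cc2)n1` gives 58%. Among the measured compounds shown here, the only measured step is a number 12 percentage points higher from compound 1 to compound 2 (beyond the scatter), ethyl against 3-fluorophenyl. Compound 3 `COc1ccc(-n2nc(C(=O)Nc3ccc(C(F)(F)F)cc3)nc2-c2cc(OC)c(OC)c(OC)c2)cc1` differs from compound 2 in one place: 4-(trifluoromethyl)phenyl in place of 3-fluorophenyl on an amide-type nitrogen. For the measured compounds named here, no measured step exchanges one aryl group for another on that nitrogen, so the step from compound 1 bears only loosely, showing only that the number with an aryl group on that nitrogen is higher than with ethyl. One therefore expects no change beyond the scatter, a number 2 percentage points lower from compound 2 to compound 3 (within the scatter). The estimate for compound 3 is 68%, within 55% to 80%.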

Compound 3, a percentage reported as inhibition, in the whole organism at one dose (the size of the read-out at that dose, not a potency): 56%
The estimate for compound 3 lay 12 percentage points above the measured number, within the range that was stated.
By their numbers in this assay, from the lowest: compounds 3 and 1 (each within the scatter of the next); then compound 2.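

In this assay, the aryl groups on the amide-type nitrogen prove not to be interchangeable: exchanging 3-fluorophenyl for 4-(trifluoromethyl)phenyl gives a number 14 percentage points lower from compound 2 to compound 3 (beyond the scatter) at this position. An aryl group there does not by itself raise the number over ethyl, since the exchange of ethyl for 4-(trifluoromethyl)phenyl gives a number 2 percentage points lower from compound 1 to compound 3 (within the scatter) in this comparison. Nothing measured here accounts for the gap between the two aryl groups. From the compounds shown here alone, it remains open whether a plain phenyl or a 4-fluorophenyl on that nitrogen would stand with compound 2 or with compound 3. A longer alkyl chain such as butyl is also left open.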